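4-Bromo-2-fluorophenyl for Phenyl on Two Cores

This account rests on a few compounds, and the source may have more. Where it says the series, first, only, none or still open, it means among the compounds named here.

Compound 1 `O=C(Nc1ccc(Oc2ccnc3[nH]ccc23)cc1)c1nn(-c2ccccc2)ccc1=O` was tested in a functional assay on A549 cells (Homo sapiens) for cytotoxicity, read by MTT assay, with a stated time of 72 h (a lower number here means a stronger inhibitor, a higher number a weaker inhibitor), where compound 1 gives 10500 nM. Its partner compound 2 `O=C(Nc1ccc(Oc2ccnc3[nH]ccc23)cc1)c1nn(-c2ccc(Br)cc2F)ccc1=O` gives 26100 nM in this assay. The change between them is 4-bromo-2-fluorophenyl in place of phenyl on an aromatic nitrogen, and it made a step of a 2.5-fold higher number from compound 1 to compound 2 (0.40 log units; beyond the scatter). Compound 3 `Cn1ccc2c(Oc3ccc(NC(=O)c4nn(-c5ccccc5)ccc4=O)cc3F)ccnc21` rests on a different core; the difference between the two cores is not broken down here. For compound 3 this assay reports only a limit, > 60000 nM. Compound 4 `Cn1ccc2c(Oc3ccc(NC(=O)c4nn(-c5ccc(Br)cc5F)ccc4=O)cc3F)ccnc21` carries the same change, (4-bromo-2-fluorophenyl in place of phenyl on an aromatic nitrogen), in the same surroundings. Given the earlier step of a 2.5-fold higher number from compound 1 to compound 2 (0.40 log units; beyond the scatter), a similar weakening step is expected for compound 4, namely a step that the limit leaves unreadable from compound 3 to compound 4. Because compound 3 already sits at the limit (the limit of > 60000 nM in this assay, at which 1 of the 3 values shown sits), compound 4 is expected to return a limit too, with a middle estimate of 120000 nM and a range from 50000 nM to 400000 nM.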

Compound 4, half-maximal inhibitory concentration: 26800 nM
Compound 4: the middle estimate sits 4.5-fold (0.65 log units) above what was measured; measured number below the stated range.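

In this assay, 4-bromo-2-fluorophenyl in place of phenyl gave an at least 2.2-fold lower number from compound 3 to compound 4 (0.35 log units; beyond the scatter), the opposite direction to the step on the core of compound 1. The two steps differ: the same change on two cores in this assay, a 2.5-fold higher number (0.40 log units; beyond the scatter) from compound 1 to compound 2 and an at least 2.2-fold lower number (0.35 log units; beyond the scatter) from compound 3 to compound 4, at least 5.5-fold (0.74 log units) apart, beyond the scatter of two such steps. This shows that the direction of this change did not carry from one core to the other, but it rests on a single pair of cores, the value for compound 3 is only a limit, leaving the true size of the step unknown, and it does not show why the cores differ.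

The compounds shown leave open which difference between the two cores reverses the step, and whether bromine or fluorine alone would do the same. On these data alone, how a phenyl carrying an amine or a carboxylic acid would behave on either core also stays open.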